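Swapping Hydroxymethyl for Amino on a Shared Core

The source may report more compounds than this note shows. Statements on the series, on what has been measured and on what is new or still open speak of the compounds shown alone.

Compound 1 `Fc1ccc(C2(c3ccc(F)cc3)CNC(c3ccccc3)=N2)cc1`: 32 nM
Compound 2 `O=[N+]([O-])c1cccc(C2=NC(c3ccc(F)cc3)(c3ccc(F)cc3)CN2)c1`: 4.3 nM
Compound 3 `OCc1cccc(C2=NC(c3ccc(F)cc3)(c3ccc(F)cc3)CN2)c1`: 59 nM

In an assay on LM cells for displacement of a labelled ligand from Neuropeptide Y receptor type 5 (Homo sapiens) (a lower number here means a stronger inhibitor, a higher number a weaker inhibitor), compound 3 gives the highest number of the three. Compound 1 sits close to it, within the scatter, while compound 2 lies well below it, as seen in a 14-fold higher number from compound 2 to compound 3 (1.14 log units; beyond the scatter). Compound 4 `Nc1cccc(C2=NC(c3ccc(F)cc3)(c3ccc(F)cc3)CN2)c1` differs from compound 3 by amino in place of hydroxymethyl on an aromatic carbon. Among the measured compounds shown here, the steps that bear on this carbon are a 1.8-fold higher number from compound 1 to compound 3 (0.27 log units; within the scatter), within the scatter, and a 7.4-fold lower number from compound 1 to compound 2 (0.87 log units; beyond the scatter), beyond it, so a group here can shift the number a great deal or hardly at all. For the measured compounds named here, no measured step shows what amino itself does, so only a modest move toward a lower number is expected, and for compound 4 the expected change is a 2.4-fold lower number from compound 3 to compound 4 (0.37 log units; beyond the scatter). The estimate for compound 4 in this assay is 25 nM, with a range from 6 nM to 100 nM.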

Compound 4, half-maximal inhibitory concentration: 300 nM
Compound 4: the middle estimate sits 12-fold (1.08 log units) below what was measured; the whole stated range lies below it.
By their numbers in this assay, from the lowest: compound 2; then compounds 1 and 3 (each within the scatter of the next); then compound 4.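

In this assay, amino is the only group shown at this aromatic carbon that clearly raises the number over plain hydrogen, with a 9.4-fold higher number from compound 1 to compound 4 (0.97 log units; beyond the scatter), so a group here can push the number either way. The two extremes are nitro and amino, with a 70-fold higher number from compound 2 to compound 4 (1.84 log units; beyond the scatter), a wide spread for a single substituent. Even the swap from hydroxymethyl gives a 5.1-fold higher number from compound 3 to compound 4 (0.71 log units; beyond the scatter), and no evidence here explains why.

From the compounds shown here alone, whether a methylamino or acetamido group would behave like amino remains open. So does whether a carboxylic acid or nitrile would track nitro.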